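Inverting one chain stereocentre of compound 2

The source may hold more compounds than are shown below. What is called first, only, known or untested is meant among the compounds shown, and "the series" means these compounds.

These notes follow the series in an ADME assay on HFF cells (Homo sapiens) for cytotoxicity, read by neutral red uptake; on this read-out lower numbers stand for higher toxicity in this test and higher numbers for lower toxicity in this test. Compound 1 `Nc1nc2c(ncn2/C=C2/C[C@@H]2[C@@H](O)CO)c(=O)[nH]1` gives > 300000 nM, which is a limit of the assay and not a number. Compound 2 `Nc1ncnc2c1ncn2/C=C1\C[C@@H]1[C@H](O)CO` gives > 300000 nM, which is likewise a limit and not a number. Compound 2 therefore has no exact position on the scale, and the record so far is the limit of > 300000 nM in this assay, at which 2 of the 2 values shown sit.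

Compound 3 `Nc1ncnc2c1ncn2/C=C1\C[C@@H]1[C@@H](O)CO` is the next to be read, and its relation to compound 2 is a change of configuration only: the two compounds have the same atoms and bonds and differ only in configuration as drawn: 1 of 3 stereo elements differ; a stereocentre at a saturated chain carbon is drawn S in compound 2 and R in compound 3. Within the data shown here, no measured step shows what such a change does in this assay. The expectation rests on compound 2 alone, whose limit is > 300000 nM. The step of a number no higher from compound 2 to compound 3 (the limit leaves the size open) is expected to stay within the usual scatter, with neither direction favoured. Compound 3 is estimated at 300000 nM, with an expected range of 200000 nM to 500000 nM, and the read-out is expected to be reported as a limit again rather than as a number.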

Compound 3, half-maximal cytotoxic concentration: > 300000 nM
Compound 3: only a limit was reported; the forecaster's own chance of this, stated with the estimate: 90%; the middle value sits exactly at the limit.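

In this assay, compound 2 and compound 3 are both reported only as limits, so no step can be read between them. The compounds shown leave open whether inverting this chain stereocentre changes the read-out at all, and the record stands as follows: the limit of > 300000 nM in this assay, at which 3 of the 3 values shown sit.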